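Azole swap on the urea-methylene arm

The source may report more compounds than this note shows. Statements on the series, on what has been measured and on what is new or still open speak of the compounds shown alone.

The series shares one core, seen in compound 2 `CCOC(=O)c1ccc(NC(=O)NCc2cn[nH]c2)cc1`, an aryl urea carrying an azolylmethyl group on the second urea nitrogen. Going by the values given here, in an assay on isolated protein for activation of Nicotinamide phosphoribosyltransferase (Homo sapiens) (on this read-out higher numbers stand for an effect only at larger amounts of compound and lower numbers for an effect already at smaller amounts), compound 2 gives 1850 nM, the lowest of the two numbers measured; its only neighbour is compound 1 `CCOC(=O)c1ccc(NC(=O)NCc2cc[nH]n2)cc1`, which in this assay gives 69000 nM. Among the compounds with values here, the one measured step, a 37-fold lower number from compound 1 to compound 2 (1.57 log units; beyond the scatter), shows that the attachment point of the azole alone moves the number a great deal.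

Compound 3 `CCOC(=O)c1ccc(NC(=O)NCc2cnco2)cc1` introduces (1,3-oxazol-5-yl in place of 1H-pyrazol-4-yl on a saturated chain carbon bound to an amide-type nitrogen). Within the data shown here, no measured step addresses the loss of the ring hydrogen-bond donor or the exchange of a ring nitrogen for oxygen, so the large sensitivity seen in the step from compound 1 to compound 2 is the only guide, and it argues for a wide range. For compound 3 a weaker outcome is expected, the step of a 4.9-fold higher number from compound 2 to compound 3 (0.69 log units; beyond the scatter) moving it toward compound 1, with the value expected near 9000 nM and the range 1500 nM to 50000 nM.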

Compound 3, half-maximal effective concentration: 6900 nM
The estimate for compound 3 lay 1.3-fold (0.12 log units) above the measured number; low and high end bracket the measured number.
By their numbers in this assay, from the lowest: compound 2; then compound 3; then compound 1.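

In this assay, exchanging 1H-pyrazol-4-yl for 1,3-oxazol-5-yl gives a 3.7-fold higher number from compound 2 to compound 3 (0.57 log units; beyond the scatter), while exchanging 1H-pyrazol-3-yl for the same group gives a 10-fold lower number from compound 1 to compound 3 (1.00 log units; beyond the scatter), so the oxazole arm falls inside the span set by the two pyrazole arms. The presence of a ring hydrogen-bond donor therefore does not order the three compounds on its own: 1,3-oxazol-5-yl has 0 hydrogen-bond donors, yet compound 3 has the lower number than compound 1, though not than compound 2. Nothing at hand explains this ranking.

Still open, as far as these compounds go, is whether this order of azoles holds with a longer chain in place of the single methylene on the urea nitrogen. Also open, from the compounds shown here alone, is whether it survives a carboxylic acid in place of the ethyl ester.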